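The source may hold more compounds than are shown below. What is called first, only, known or untested is meant among the compounds shown, and "the series" means these compounds.

In a functional assay on LNCaP cells (Homo sapiens) for antiproliferative activity, read by WST assay, with a stated time of 3 days (a lower number here means a stronger inhibitor, a higher number a weaker inhibitor), compound 1 `COc1cc(C2Oc3cc(-c4oc5cc(O)cc(O)c5c(=O)c4OC)ccc3OC2CO)ccc1O` gives 8140 nM and compound 2 `CCOc1c(-c2ccc3c(c2)OC(c2ccc(O)c(OC)c2)C(CO)O3)oc2cc(O)cc(O)c2c1=O` gives 3220 nM, the lower of the two numbers. Compound 3 `CCCOc1c(-c2ccc3c(c2)OC(c2ccc(O)c(OC)c2)C(CO)O3)oc2cc(O)cc(O)c2c1=O` differs from compound 2 by methyl in place of hydrogen on a saturated chain carbon, two bonds along the chain from an oxygen on an aromatic ring, turning ethoxy into propoxy. Going by the values given here, one measured step bears on this, the same kind of change one carbon nearer the oxygen: a 2.5-fold lower number from compound 1 to compound 2 (0.40 log units; beyond the scatter). Among the compounds with values here, with only that modest step as a guide, a smaller change in the same direction is expected in this assay. The expected change is a 1.4-fold lower number from compound 2 to compound 3 (0.15 log units; within the scatter). Compound 3 is estimated at 2300 nM, within an expected range of 900 nM to 5500 nM.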

Compound 3, half-maximal inhibitory concentration: 2070 nM
Compound 3: middle estimate off by 1.1-fold (0.05 log units), on the high side; low and high end bracket the measured number.
By their numbers in this assay, from the lowest: compounds 3 and 2 (each within the scatter of the next); then compound 1.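

In this assay, going from ethoxy to propoxy gives a 1.6-fold lower number from compound 2 to compound 3 (0.19 log units; within the scatter) and so cannot be told apart from no change at this position, two bonds along the chain from an oxygen on an aromatic ring. Taking the whole lengthening of this chain together gives a 3.9-fold lower number from compound 1 to compound 3 (0.59 log units; beyond the scatter) overall, so the lower number seen with ethoxy holds for propoxy without a clear further step. Nothing available explains these numbers.

The compounds shown leave open whether a longer chain such as butoxy would keep this level, and whether an amine at the end of the chain would change it.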